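Series notes: methoxy in place of fluoro

This account rests on a few compounds, and the source may have more. Where it says the series, first, only, none or still open, it means among the compounds named here.

Compound 1 `COc1cc2c(Oc3ccc(NC(=O)c4cc(-c5ccccc5)ccn4)cc3F)ccnc2cc1OCCCN1CCN(C)CC1` carries an unsubstituted phenyl; in a functional assay on MKN-45 cells (Homo sapiens) for cytotoxicity, read by MTT assay, with a stated time of 72 h (a higher number here means a weaker inhibitor, a lower number a stronger inhibitor), compound 1 gives 150 nM. Compound 2 `COc1cc2c(Oc3ccc(NC(=O)c4cc(-c5ccc(F)cc5)ccn4)cc3F)ccnc2cc1OCCCN1CCN(C)CC1` differs only by fluoro in place of hydrogen on an aromatic carbon, and in this assay compound 2 gives 510 nM. Going by the values given here, the single measured step, a 3.4-fold higher number from compound 1 to compound 2 (0.53 log units; beyond the scatter), places compound 2 at the higher of the two numbers so far, set apart from compound 1 by more than the scatter.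

Compound 3 `COc1ccc(-c2ccnc(C(=O)Nc3ccc(Oc4ccnc5cc(OCCCN6CCN(C)CC6)c(OC)cc45)c(F)c3)c2)cc1` is the next point: methoxy in place of fluoro on an aromatic carbon. Among the compounds with values here, no measured step in this set bears directly on methoxy at that carbon; the only related information is the step from compound 1 to compound 2, which shows that changing the substituent at this position can move this assay by a modest amount. With nothing to indicate direction, the expectation is a number for compound 3 close to that of compound 2, with a step of a 1.3-fold lower number from compound 2 to compound 3 (0.11 log units; within the scatter) that may well sit within the scatter.

Compound 3 is therefore estimated at 400 nM in this assay, with a range from 150 nM to 1200 nM.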

Compound 3, half-maximal inhibitory concentration: 250 nM
For compound 3 the middle estimate is 1.6-fold (0.20 log units) above the measured one; low and high end bracket the measured number.
By their numbers in this assay, from the lowest: compounds 1 and 3 (each within the scatter of the next); then compound 2.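

In this assay the change from 4-fluorophenyl to 4-methoxyphenyl gives a 2.0-fold lower number from compound 2 to compound 3 (0.31 log units; beyond the scatter) and so shows that this carbon, para to a large group, responds to which substituent it carries, not merely to whether it carries one. Set against the unsubstituted phenyl, the record reads a 1.7-fold higher number from compound 1 to compound 3 (0.22 log units; within the scatter) and methoxy therefore cannot be told apart from hydrogen here, whereas fluoro can, as a 3.4-fold higher number from compound 1 to compound 2 (0.53 log units; beyond the scatter) shows, which leaves compound 2 as the only one of the three standing apart. Nothing available explains why fluoro and methoxy part in this way.

With only two substituents on this carbon, the shown compounds do not settle whether the higher number of compound 2 is peculiar to fluoro or shared by other halogens such as chloro, nor how an amine, a carboxylic acid or a longer chain such as ethoxy would read here. Also open, as far as these compounds go, is whether the same fluoro and methoxy steps would hold on the other carbons of this ring, and whether they would carry over to any read-out other than this cell assay.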